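Aryl hydroxylation in a nucleoside series with no measured cytotoxicity

The source may hold more compounds than are shown below. What is called first, only, known or untested is meant among the compounds shown, and "the series" means these compounds.

Compound 1 `COc1cccc(CNc2ncnc3c2ncn3[C@@H]2O[C@H](CO)[C@@H](O)[C@H]2O)c1` is one of two measured members of the series. In an ADME assay on NIH3T3 cells (Mus musculus) for cytotoxicity, with a stated time of 72 h (on this read-out lower numbers stand for stronger inhibition and higher numbers for weaker inhibition), compound 1 reaches only a limit, > 166000 nM. Compound 2 `OC[C@H]1O[C@@H](n2cnc3c(NCc4cc(F)cc(F)c4)ncnc32)C(O)C1O` likewise reaches only a limit, > 166000 nM. Both measured values sit at the limit of > 166000 nM in this assay, at which 2 of the 2 values shown sit, so no number places compound 1 against any neighbour in this assay. Compound 3 `COc1cccc(CNc2ncnc3c2ncn3[C@@H]2O[C@H](CO)[C@@H](O)[C@H]2O)c1O` is not yet measured; it differs from compound 1 by hydroxy in place of hydrogen on an aromatic carbon. Given two values at the limit, the expected step is a step that the limit leaves unreadable from compound 1 to compound 3, with nothing beyond the scatter in this assay. Compound 3 is estimated at 200000 nM, within 80000 nM to 500000 nM, most probably reported again as a limit.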

Compound 3, half-maximal inhibitory concentration: > 166000 nM
Compound 3: no number, only a limit; the forecaster's own chance of this, stated with the estimate: 80%; the middle value does not contradict the limit.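

Compound 3, like compound 1, gives only a limit in this assay, so no step between them can be read: the limit of > 166000 nM in this assay, at which 3 of the 3 values shown sit.

The compounds shown leave open at what concentration, if any, this series becomes cytotoxic, and whether the added hydroxy changes that.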